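Sulfonamide headgroup swap in a coumarin enaminone series

The source may hold more compounds than are shown below. What is called first, only, known or untested is meant among the compounds shown, and "the series" means these compounds.

Compound 1 `CC(=O)NS(=O)(=O)c1ccc(N/C=C\C(=O)c2cc3ccccc3oc2=O)cc1` belongs to the series, but in a functional assay on T47D cells (Homo sapiens) for cytotoxicity, read by sulforhodamine B assay, with a stated time of 48 h (a higher number here means a weaker inhibitor, a lower number a stronger inhibitor), compound 1 has no result reported. Among the compounds with values here, compound 2 `O=C(/C=C\Nc1ccc(S(=O)(=O)Nc2ccccn2)cc1)c1cc2ccccc2oc1=O` is therefore the only member with a number, giving 37600 nM in this assay. Within the data shown here, with a single value there is no step between measured compounds, so compound 2 stands alone and cannot be placed relative to anything else.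

Compound 3 `Cc1ccnc(NS(=O)(=O)c2ccc(N/C=C\C(=O)c3cc4ccccc4oc3=O)cc2)n1` is the next entry: 4-methylpyrimidin-2-yl in place of pyridin-2-yl on a sulfonamide nitrogen, that is, 4-methylpyrimidin-2-yl in place of pyridin-2-yl on the sulfonamide nitrogen, with the rest of the shared core untouched. Among the measured compounds shown here, no measured pair shows what such a headgroup change does in this assay, so the expectation rests only on the value of compound 2 and the modest size of the change. The step from compound 2 to compound 3 is estimated as a 1.2-fold lower number from compound 2 to compound 3 (0.07 log units; within the scatter), no more than the usual scatter in either direction. Compound 3 is expected to give around 32000 nM in this assay, with a plausible range from 10000 nM to 100000 nM.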

Compound 3, half-maximal inhibitory concentration: 24500 nM
Compound 3: middle estimate off by 1.3-fold (0.12 log units), on the high side; the measured number falls inside the stated range.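

In this assay, within the data shown here, the first readable step at this position is a 1.5-fold lower number from compound 2 to compound 3 (0.19 log units; within the scatter), so on the sulfonamide nitrogen pyridin-2-yl and 4-methylpyrimidin-2-yl cannot be told apart, with compound 2 at 37600 nM and compound 3 at 24500 nM. The exchange takes the group from 6 heavy atoms to 7 and from 1 hydrogen-bond acceptor to 2, and this difference leaves the two values within the scatter of each other. Nothing in hand bears on why these two groups read alike.

Any step to compound 1 cannot be read, so the acetyl group on the sulfonamide nitrogen remains unplaced against pyridin-2-yl and 4-methylpyrimidin-2-yl. Also open, from the compounds shown here alone, is whether a different kind of group on that nitrogen, such as a plain phenyl ring or a short chain ending in a carboxylic acid, would move the number in this assay beyond the scatter, as the two readable compounds carry only six-membered aromatic rings with ring nitrogen there.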